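The source may hold more compounds than are shown below. What is called first, only, known or untested is meant among the compounds shown, and "the series" means these compounds.

Working notes on the series, all read in a functional assay on MT4 cells (Homo sapiens) for cytotoxicity (a lower number here means that less compound is tolerated, a higher number that more compound is tolerated), where compound 1 `CCC(C)Sc1nc(O)cc(C(C)c2ccccc2)n1` gives 200000 nM as a measured number. Compound 2 `CC(c1cc(O)nc(SC2CCCCC2)n1)c1c(Cl)cccc1Cl` reads > 200000 nM and this is a limit of the assay, not a number. Compound 3 `CCCCSc1nc(O)cc(C(C)c2c(F)cccc2F)n1` reads > 200000 nM and this too is only a limit. Compound 3 therefore stands at the limit, with no exact value to start from, and no measured step links any two of these compounds.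

Compound 4 `CC(c1cc(O)nc(SC2CCCCC2)n1)c1c(F)cccc1F` follows from compound 3 by one change, cyclohexyl in place of butyl on a sulfur with the rest of the structure kept. Compound 2 also carries cyclohexyl on a sulfur and still reads > 200000 nM as a limit. For compound 4 no sizeable drop in this assay is expected because the limit of > 200000 nM in this assay, at which 2 of the 3 values shown sit, and the change itself gives no ground for a shift in either direction. The expected size of a number no higher from compound 3 to compound 4 (the limit leaves the size open) is nothing beyond the usual scatter, and a report as a limit again is quite likely. For compound 4 the estimated value is 200000 nM with an expected range of 90000 nM to 250000 nM in this read-out.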

Compound 4, half-maximal cytotoxic concentration: > 200000 nM
Compound 4: a limit, no number; the forecaster's own chance of this, stated with the estimate: 70%; the middle value lies on the limit itself.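

Neither step into compound 4, from compound 3 or from compound 2, can be read, because all three compounds stand at a limit and give no number: the limit of > 200000 nM in this assay, at which 3 of the 4 values shown sit.

The compounds shown leave open how compound 2, compound 3 and compound 4 truly compare in this assay, and whether cyclohexyl in place of butyl on a sulfur, or 2,6-difluorophenyl in place of 2,6-dichlorophenyl, changes the reading at all.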